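Replacing a methylphenyl group by a fluorophenyl group

The compounds below may be only part of what the source reports. "The series", "measured", "known", "first", "only" and "open" are said of these compounds alone.

Measured so far:
Compound 1, `N=C(N)c1ccc(-c2ccc(-c3cccc([N+](=O)[O-])c3)o2)cc1`: 28 nM
Compound 2, `Cc1ccc(-c2ccc(-c3ccc(C(=N)N)cc3)o2)cc1`: 110 nM

Both numbers come from an assay on isolated protein for inhibition of ribosyldihydronicotinamide dehydrogenase [quinone] (Homo sapiens), read by spectrophotometry, with a stated time of 1 min; on this read-out lower numbers stand for stronger inhibition and higher numbers for weaker inhibition. Compound 2 stands at the higher of the two numbers; compound 1 sits lower, and the gap between them lies beyond the usual scatter, so compound 2 is the weaker inhibitor of this pair.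

Compound 3, `N=C(N)c1ccc(-c2ccc(-c3cccc(F)c3)o2)cc1`, is not yet measured. It differs from compound 2 in one place: 3-fluorophenyl in place of 4-methylphenyl on an aromatic carbon. Among the measured compounds shown here, no measured pair differs in exactly this way, so the size of the step is uncertain. For the measured compounds named here, the only guide is that compound 1, which carries a 3-fluorophenyl-like pattern of substitution with a 3-nitrophenyl group, gave 28 nM.

The step of a 1.8-fold lower number from compound 2 to compound 3 (0.26 log units; within the scatter) is expected to be small, quite possibly within the scatter. Compound 3 is estimated at 60 nM, within a range from 20 nM to 180 nM.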

Compound 3, half-maximal inhibitory concentration: 111 nM
Compound 3: the middle estimate sits 1.9-fold (0.27 log units) below what was measured; the range from low to high includes it.
By their numbers in this assay, from the lowest: compound 1; then compounds 2 and 3 (each within the scatter of the next).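

In this assay, the exchange of 4-methylphenyl for 3-fluorophenyl on this aromatic carbon next to the ring oxygen gives a 1.0-fold higher number from compound 2 to compound 3 (0.00 log units; within the scatter) and so shows no measurable difference between these two groups. Exchanging only nitro for fluoro gives a 4.0-fold higher number from compound 1 to compound 3 (0.60 log units; beyond the scatter) in a step that lies beyond the scatter, so among these three compounds the lower number goes with the 3-nitrophenyl group of compound 1 and is not shared by the other two phenyl groups. Nothing available here offers an explanation for either step.

Since compound 2 and compound 3 differ in both the group and where it sits on the phenyl ring, a 3-methylphenyl or 4-fluorophenyl group would be needed to separate the two. From the compounds shown here alone, whether an amine or a carboxylic acid in place of the nitro group would match compound 1 also remains open.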